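The compounds below may be only part of what the source reports. "The series", "measured", "known", "first", "only" and "open" are said of these compounds alone.

Of the compounds shown here, three built on one shared core have been tested in a toxicity assay on HepG2 2.2.15 cells (Homo sapiens) for cytotoxicity, read by CellTiter-Glo; on this read-out lower numbers stand for higher toxicity in this test and higher numbers for lower toxicity in this test. Compound 1 `CC1CCn2ncc(N3CC(c4ccccc4)CC3=O)c2CN1C(=O)Nc1cc(F)c(F)c(F)c1` gives only a limit there, > 2000 nM. Compound 2 `Cc1cnc(C2CC(=O)N(c3cnn4c3CN(C(=O)Nc3cc(F)c(F)c(F)c3)C(C3CC3)C4)C2)s1` gives 96200 nM. Among the compounds with values here, compound 3 `O=C1CC(c2ccc(F)cc2)CN1c1cnn2c1CN(C(=O)Nc1cc(F)c(F)c(F)c1)C(C1CC1)C2` gives 32100 nM, the lowest of the two numbers measured so far. Within the data shown here, the single measured step that joins two numbers, a 3.0-fold lower number from compound 2 to compound 3 (0.48 log units; beyond the scatter), exchanges the whole aryl group on the saturated ring carbon and is a modest move.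

Compound 4 `O=C1CC(c2ccccc2)CN1c1cnn2c1CN(C(=O)Nc1cc(F)c(F)c(F)c1)C(C1CC1)C2` differs from compound 3 in a far smaller way: hydrogen in place of fluoro on an aromatic carbon. Among the measured compounds shown here, no measured step in this set removes a single fluoro. Compound 1 carries a phenyl as compound 4 does, but it also differs from compound 4 elsewhere on the shared core and gives only a limit, so it offers no number to lean on. Since even a full exchange of the aryl group moves the number only modestly, the loss of one fluoro is expected to move it no further than that, with no clear direction.

Compound 4 is therefore expected to give 35000 nM, with a range from 12000 nM to 90000 nM. The expected step of a 1.1-fold higher number from compound 3 to compound 4 (0.04 log units; within the scatter) would stay close to the scatter.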

Compound 4, half-maximal cytotoxic concentration: 12800 nM
The estimate for compound 4 lay 2.7-fold (0.44 log units) above the measured number; the range from low to high includes it.
By their numbers in this assay, from the lowest: compound 4; then compound 3; then compound 2.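

The earlier compounds shown here showed only that exchanging the whole aryl group on the saturated ring carbon moves the number in this assay. Compound 4 shows that a far smaller change at the same site also counts: taking away one fluoro, on the aromatic carbon para to a large group, gives a 2.5-fold lower number from compound 3 to compound 4 (0.40 log units; beyond the scatter), a step beyond the scatter and of the same modest class as the whole exchange. Phenyl also gives a 7.5-fold lower number from compound 2 to compound 4 (0.88 log units; beyond the scatter), so among the three compounds with numbers, the order on this site runs from phenyl at the lowest through 4-fluorophenyl to 5-methyl-1,3-thiazol-2-yl at the highest, and a lower number here stands for higher toxicity in this test.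

From the compounds shown here alone, compound 1 also carries a phenyl, but it differs elsewhere on the shared core, and its place in this order stays open as its result is a limit and not a number: the limit of > 2000 nM in this assay, at which 1 of the 4 values shown sits. Going by these compounds, it also remains open whether a chloro, a methoxy or an amine on that same aromatic carbon would continue this order, or would bring the number lower still than phenyl does.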